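This account rests on a few compounds, and the source may have more. Where it says the series, first, only, none or still open, it means among the compounds named here.

Compound 1 `CC(C)C[C@H](NC(=O)OC1CCC(F)(F)CC1)C(=O)N[C@H](C=O)C[C@@H]1CCNC1=O`, compound 2 `CC(C)C[C@H](NC(=O)OCC1CCC(F)(F)CC1)C(=O)N[C@H](C=O)C[C@@H]1CCNC1=O` and compound 3 `CC(C)C[C@H](NC(=O)OC1CCC(F)(F)CC1)C(=O)N[C@@H](C[C@@H]1CCNC1=O)C(O)S(=O)(=O)O` are built on the shared core; compound 4 `CC(C)C[C@H](NC(=O)OCC1CCC(F)(F)CC1)C(=O)N[C@@H](C[C@@H]1CCNC1=O)C(O)S(=O)(=O)O` has not yet been run. In a toxicity assay on L929 cells (Mus musculus) for cytotoxicity (on this read-out lower numbers stand for higher toxicity in this test and higher numbers for lower toxicity in this test), compound 1 reaches only a limit of the assay, > 100000 nM. Compound 2 likewise returns a limit in this assay, > 100000 nM. Compound 3 also stops at a limit, > 100000 nM. The change (4,4-difluorocyclohexyl)methyl in place of 4,4-difluorocyclohexyl on an oxygen next to a carbonyl group leaves a step that the two limits leave unreadable from compound 1 to compound 2. The cores of compound 1 and compound 3 differ by hydroxy(sulfo)methyl in place of formyl on a saturated chain carbon bound to an amide-type nitrogen and a saturated chain carbon, giving a step that the two limits leave unreadable from compound 1 to compound 3. The change from compound 3 to compound 4, ((4,4-difluorocyclohexyl)methyl in place of 4,4-difluorocyclohexyl on an oxygen next to a carbonyl group), is the same change as that from compound 1 to compound 2, at a place described in identical words. For compound 4 the expected step is a number no higher from compound 3 to compound 4 (the limit leaves the size open), which rests on (the limit of > 100000 nM in this assay, at which 3 of the 3 values shown sit). Compound 4 is therefore estimated in this assay at about 100000 nM, most probably again reported only as a limit.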

Compound 4, half-maximal cytotoxic concentration: > 100000 nM
Compound 4 was reported as a limit (the forecaster's own chance of this, stated with the estimate: 85%); the middle value sits exactly at the limit.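

Among these compounds, compound 4 stops at a limit in this assay of > 100000 nM and so no step to it from compound 3 or compound 2 can be read. The compounds shown leave open in this assay whether and at what concentration any of them shows toxicity.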